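A few compounds are considered here, and "the series" means these few. Any claim that something is new, unique, unknown or untested is made for them only; others in the source may bear on it.

Compound 1 `CCn1c(-c2cnc(C)nc2)nc2c(N[C@H]3CCN(C(=O)[C@H]4C[C@@H](OC)C4)C3)ncnc21`: 6.9 mL/min/kg
Compound 2 `CCn1c(-c2cnc(C)nc2)nc2c(O[C@H]3CCN(C(=O)N4CC(OC)C4)C3)ncnc21`: 4 mL/min/kg

In an ADME assay on the whole organism (Rattus norvegicus, strain Wistar Han) for pharmacokinetics (on this read-out higher numbers stand for fast clearance and lower numbers for slow clearance), compound 1 gives 6.9 mL/min/kg and compound 2 gives 4 mL/min/kg. These two values lie within the usual scatter of each other, so compound 1 cannot be told apart from compound 2. Compound 3 `CCn1c(-c2cnc(C)nc2)nc2c(N[C@H]3CCN(C(=O)C4CC4)C3)ncnc21` keeps the core of compound 1 but has cyclopropyl in place of 3-methoxycyclobutyl on a carbonyl carbon. For the measured compounds named here, no measured pair shows this change, so the expectation in this assay is no shift beyond the scatter, in either direction. The expected step is a 1.1-fold higher number from compound 1 to compound 3 (0.04 log units; within the scatter). Compound 3 is estimated at 7.5 mL/min/kg, with an expected range of 3.5 mL/min/kg to 16 mL/min/kg.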

Compound 3, clearance: 8.1 mL/min/kg
The estimate for compound 3 lay 1.1-fold (0.03 log units) below the measured number; low and high end bracket the measured number.
By their numbers in this assay, from the lowest: compounds 2, 1 and 3 (each within the scatter of the next, the first and the last beyond it).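

In this assay cyclopropyl in place of 3-methoxycyclobutyl on a carbonyl carbon gives a 1.2-fold higher number from compound 1 to compound 3 (0.07 log units; within the scatter) and so cannot be told from no change. At this position, the group on the carbonyl can therefore lose its methoxy and its defined stereocentres with no clear shift in clearance. Nothing measured here explains this result.

This is a single pair, so it says nothing yet about other kinds of group. An amine or a longer chain on the same carbonyl carbon could behave differently.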